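Fluoro to hydrogen on compound 3

This account rests on a few compounds, and the source may have more. Where it says the series, first, only, none or still open, it means among the compounds named here.

In an ADME assay on MRC5 cells (Homo sapiens) for cytotoxicity, read by fluorescence and resazurin assay, with a stated time of 3 days (a higher number here means that more compound is needed for the effect, a lower number that less compound is needed), compound 1 (`C#CC1(O)C=CC(=O)C=C1`) gives 2100 nM and compound 2 (`COc1ccc(-n2cc(C3(O)C=CC(=O)C=C3)nn2)cc1`) gives 310 nM. Compound 3 (`O=C1C=CC(O)(c2cc3ccc(F)cc3n2S(=O)(=O)c2ccccc2)C=C1`) gives 170 nM, a number within the scatter of compound 2 and lower than that of compound 1 by more than the scatter. Compound 4 (`O=C1C=CC(O)(c2cc3ccccc3n2S(=O)(=O)c2ccccc2)C=C1`) carries hydrogen in place of fluoro on an aromatic carbon. Going by the values given here, no measured pair isolates this kind of change, so the expectation in this assay is for no step beyond the scatter, in either direction. The estimated change is a 1.2-fold higher number from compound 3 to compound 4 (0.07 log units; within the scatter). For compound 4 the estimated value is 200 nM, with an expected range of 90 nM to 430 nM.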

Compound 4, half-maximal effective concentration: 110 nM
Compound 4: the middle estimate sits 1.8-fold (0.26 log units) above what was measured, and the stated range covers the measured number.
By their numbers in this assay, from the lowest: compounds 4, 3 and 2 (each within the scatter of the next, the first and the last beyond it); then compound 1.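

In this assay, going by these compounds alone, this is the first pair to isolate one change, and it gives a 1.5-fold lower number from compound 3 to compound 4 (0.19 log units; within the scatter). On this aromatic carbon, then, hydrogen in place of fluoro leaves the number within the scatter, so a number of this size does not depend on the fluoro. Nothing available here offers an explanation for this result. As far as these compounds go, whether an amine, a methoxy group or a carboxylic acid on this carbon would move the number beyond the scatter remains open. So does whether fluoro on another carbon of this ring would behave the same way.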